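A few compounds are considered here, and "the series" means these few. Any claim that something is new, unique, unknown or untested is made for them only; others in the source may bear on it.

Series notes. The shared core of compound 1 `COc1ccc(-n2c(=O)n(Cc3cc4cc(Cl)ccc4n3CCCC#N)c3cnccc32)c(C)c1` carries a 4-methoxy-2-methylphenyl on an aromatic nitrogen; compound 2 `CS(=O)(=O)c1ccc(-n2c(=O)n(Cc3cc4cc(Cl)ccc4n3CCCC#N)c3cnccc32)cc1` carries a 4-(methylsulfonyl)phenyl there, and compound 3 `N#CCCCn1c(Cn2c(=O)n(C3CC3)c3ccncc32)cc2cc(Cl)ccc21` a cyclopropyl. In an ADME assay on HeLa cells (Homo sapiens) for cytotoxicity, read by ATP content, with a stated time of 3 days (a higher number here means that more compound is tolerated, a lower number that less compound is tolerated), compound 1 reports only a limit, > 50000 nM. Compound 2 likewise sits at a limit in this assay, > 50000 nM. Compound 3 in this assay also gives a limit, > 50000 nM. Compound 3 thus stands on the same limit as the other two, and none of the steps between them can be read: a step that the two limits leave unreadable from compound 1 to compound 2, a step that the two limits leave unreadable from compound 1 to compound 3 and a step that the two limits leave unreadable from compound 2 to compound 3 are all hidden by the two limits. Within the data shown here, the one piece of evidence is the limit of > 50000 nM in this assay, at which 3 of the 3 values shown sit.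

Compound 4 `N#CCCCn1c(Cn2c(=O)n(-c3ccc(C(=O)O)cc3)c3ccncc32)cc2cc(Cl)ccc21` is not yet measured. It differs from compound 3 in one place: 4-carboxyphenyl in place of cyclopropyl on an aromatic nitrogen. The measured steps that bear on it are the exchanges of the group on that same aromatic nitrogen, a step that the two limits leave unreadable from compound 1 to compound 3 and a step that the two limits leave unreadable from compound 2 to compound 3, both unreadable; each exchange between an aryl and the cyclopropyl left the value at the limit. On that basis no step beyond the scatter is expected in this assay for compound 4, and the expected step is a number no higher from compound 3 to compound 4 (the limit leaves the size open). Compound 4 is therefore estimated at 50000 nM in this assay, with a range from 25000 nM to 100000 nM, most likely reported again as a limit.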

Compound 4, half-maximal cytotoxic concentration: > 50000 nM
Compound 4: a limit, no number; the forecaster's own chance of this, stated with the estimate: 85%; the middle value sits exactly at the limit.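

In this assay compound 4 gives > 50000 nM, a limit and not a number. Its steps to compound 1, compound 2 and compound 3 cannot be read, so no new step emerges: the limit of > 50000 nM in this assay, at which 4 of the 4 values shown sit.

The compounds shown leave open where any of the four truly lies beyond that limit, and whether exchanging the group on the aromatic nitrogen changes the tolerated concentration in this assay at all.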